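Phenyl in place of butyl on compound 2

This account rests on a few compounds, and the source may have more. Where it says the series, first, only, none or still open, it means among the compounds named here.

compound 1 `Cc1cccc([C@@H](O)C(=O)N2N=CC[C@H]2C(=O)NCc2cc(Cl)ccc2-n2cnnn2)c1`: 830 nM
compound 2 `CCCC[C@@H](O)C(=O)N1C[C@H]2C[C@H]2[C@H]1C(=O)NCc1cc(Cl)ccc1-n1cnnn1`: 750 nM
compound 3 `O=C(NCc1cc(Cl)ccc1-n1cnnn1)[C@@H]1C[C@@H]2C[C@@H]2N1C(=O)[C@H](O)c1ccccc1F`: 770 nM

All values come from a functional assay on a cell-free system (plasma, Homo sapiens), with a stated time of 3 min; a higher number here means a weaker inhibitor, a lower number a stronger inhibitor. Compound 2, at 750 nM, stands within the scatter of compound 1 and compound 3. Compound 4 `O=C(NCc1cc(Cl)ccc1-n1cnnn1)[C@@H]1[C@@H]2C[C@@H]2CN1C(=O)[C@H](O)c1ccccc1` differs from compound 2 by phenyl in place of butyl on a saturated chain carbon bound to a carbonyl carbon and an oxygen on a saturated carbon, with phenyl in place of butyl on a saturated chain carbon bound to a carbonyl carbon and an oxygen on a saturated carbon. Compound 1 at 830 nM and compound 3 at 770 nM also carry an aromatic ring on that carbon, though their cores differ. No step beyond the scatter is therefore expected in this assay. The expected change is a 1.1-fold lower number from compound 2 to compound 4 (0.03 log units; within the scatter). Compound 4 is estimated at 700 nM, with an expected range of 280 nM to 1700 nM.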

Compound 4, half-maximal inhibitory concentration: 700 nM
Compound 4: the middle estimate sits on the measured number at the digits printed; the measured number falls inside the stated range.
By their numbers in this assay, from the lowest: compounds 4, 2, 3 and 1 (each within the scatter of the next).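

In this assay, phenyl in place of butyl on the saturated chain carbon bound to a carbonyl carbon and an oxygen on a saturated carbon gives a 1.1-fold lower number from compound 2 to compound 4 (0.03 log units; within the scatter) on the shared core. For the compounds shown here, this is the first comparison at this position that is free of a core difference, and it does not tell the aromatic ring from the open chain. No measurement on hand accounts for this result.

Still open, from the compounds shown here alone, is whether an amine or a carboxylic acid on that carbon would give a step beyond the scatter.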